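This account rests on a few compounds, and the source may have more. Where it says the series, first, only, none or still open, it means among the compounds named here.

Compound 1 `COc1ccc(-n2nc(C(=O)Nc3ccccc3C)nc2-c2cc(OC)c(OC)c(OC)c2)cc1` gives 50% in a functional assay on the whole organism for inhibition, with Rattus norvegicus as the target, read by paw edema, with stated times of 30 min and 3 h, at a dose of 0.28 mmol/kg by the oral route (a lower number here means less inhibition, a higher number more inhibition at the dose given (going by the name of the read-out)), and compound 2 `COc1ccc(-n2nc(C(=O)Nc3ccc(C(=O)O)cc3)nc2-c2cc(OC)c(OC)c(OC)c2)cc1` gives 74%; compound 2 thus stands highest of the two numbers, with the step of a number 24 percentage points higher from compound 1 to compound 2 (beyond the scatter) lying beyond the scatter. Compound 3 `COc1ccc(-n2nc(C(=O)Nc3ccc(O)cc3)nc2-c2cc(OC)c(OC)c(OC)c2)cc1` differs from compound 2 by hydroxy in place of carboxy on an aromatic carbon. Within the data shown here, only the step from compound 1 to compound 2 bears on the amide-side aryl substituent, and it concerned a different exchange, so the evidence is thin. A small-to-modest downward step, a number 12 percentage points lower from compound 2 to compound 3 (beyond the scatter), is expected, because of the size of a number 24 percentage points higher from compound 1 to compound 2 (beyond the scatter) the hydroxy analogue is expected to lose only part of the gain. Compound 3 is estimated at 62%, range 42% to 80%.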

Compound 3, a percentage reported as inhibition, in the whole organism at one dose (the size of the read-out at that dose, not a potency): 50%
For compound 3 the middle estimate is 12 percentage points above the measured one, within the range that was stated.
By their numbers in this assay, from the lowest: compounds 1 and 3 (each within the scatter of the next); then compound 2.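

On the aromatic carbon para to a large group, hydroxy in place of carboxy gives a number 24 percentage points lower from compound 2 to compound 3 (beyond the scatter) in this assay, so the higher number of compound 2 does not carry over to the 4-hydroxyphenyl amide. Set against the 2-methylphenyl group, 4-hydroxyphenyl gives no change at the digits printed from compound 1 to compound 3 (within the scatter), so among these compounds only the 4-carboxyphenyl group stands apart. Nothing available explains the difference between carboxy and hydroxy at this place.

Open, going by these compounds, is whether an amine or a methyl ester at this place would match carboxy, and whether a longer chain ending in a carboxylic acid would keep the gain.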